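Swapping the Hydroxamic Acid End Group in Leukemia Cells

The source may report more compounds than this note shows. Statements on the series, on what has been measured and on what is new or still open speak of the compounds shown alone.

Of the compounds shown here, three have so far been tested in a functional assay on MV4-11 cells (Homo sapiens) for antiproliferative activity, read by CCK-8 assay, with a stated time of 72 h; a lower number here means a stronger inhibitor, a higher number a weaker inhibitor. Compound 1 `Cn1cc(-c2cc(C(C)(C)O)ccc2OC2CC2)c2cc(C(=O)NCc3ccc(C(=O)Nc4ccccc4N)cc3)[nH]c2c1=O` gives 40 nM in this assay. Compound 2 `Cn1cc(-c2cccc(C(C)(C)O)c2)c2cc(C(=O)NCc3ccc(C(=O)Nc4ccccc4N)cc3)[nH]c2c1=O` differs from it in one place, and the step shows a 55-fold higher number from compound 1 to compound 2 (1.74 log units; beyond the scatter); compound 2 gives 2200 nM. Compound 3 `Cn1cc(-c2ccccc2Oc2ccccc2)c2cc(C(=O)NCCCC(=O)NO)[nH]c2c1=O` gives 380 nM, the second highest of the three numbers, standing above compound 1 and below compound 2, both gaps beyond the usual scatter.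

Compound 4 `Cn1cc(-c2ccccc2Oc2ccccc2)c2cc(C(=O)NCCCCC(=O)Nc3ccccc3N)[nH]c2c1=O` has not yet been measured. It differs from compound 3 in one way: ((2-aminophenyl)carbamoyl)methyl in place of hydroxycarbamoyl on a saturated chain carbon, three bonds along the chain from an amide-type nitrogen. Within the data shown here, the single measured step, between compound 1 and compound 2, concerns a different part of the molecule and does not bear on this change. Among the measured compounds shown here, compounds 1 and 2 show only that the entering group can belong to a strong or to a weak inhibitor in this assay. For the measured compounds named here, with no comparable step in the data, compound 4 is expected to show a step of a 2.4-fold higher number from compound 3 to compound 4 (0.37 log units; beyond the scatter), toward a higher number. Compound 4 is therefore estimated at 900 nM, within a range from 200 nM to 4000 nM.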

Compound 4, half-maximal inhibitory concentration: 240 nM
Beside the measured number, compound 4's estimate is 3.8-fold (0.57 log units) above it, and the stated range covers the measured number.
By their numbers in this assay, from the lowest: compound 1; then compounds 4 and 3 (each within the scatter of the next); then compound 2.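

In this assay, this position takes the exchange of hydroxycarbamoyl for ((2-aminophenyl)carbamoyl)methyl with a 1.6-fold lower number from compound 3 to compound 4 (0.20 log units; within the scatter), so the two end groups cannot be told apart by this read-out. The entering group has more heavy atoms and adds a six-membered aromatic ring of carbon only, while the counts of hydrogen-bond donors and acceptors stay the same, and this larger group still gives a number level with the smaller one. No measurement shown here explains why the two end groups read alike.

Still open, on these data alone, is whether other end groups at this place, such as a carboxylic acid or an amine, or a longer chain, would read the same. Also open, as far as these compounds go, is whether this exchange would read alike on a core carrying the cyclopropyloxy group of compound 1.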